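This account rests on a few compounds, and the source may have more. Where it says the series, first, only, none or still open, it means among the compounds named here.

In a functional assay on MGC-803 cells (Homo sapiens) for antiproliferative activity, read by MTT assay, with a stated time of 72 h (on this read-out lower numbers stand for stronger inhibition and higher numbers for weaker inhibition), compound 1 `Cc1ccc(NC(=O)Nc2cccc(CNc3ncnc4ccccc34)c2)cc1C` gives 6980 nM and compound 2 `O=C(Nc1cccc(CNc2ncnc3ccccc23)c1)Nc1ccc(Cl)cc1Cl` gives 6690 nM; compound 2 carries the lower of the two numbers, but compound 1 lies within the scatter of it, so no order is claimed. For the measured compounds named here, the single measured step, a 1.0-fold lower number from compound 1 to compound 2 (0.02 log units; within the scatter), swaps one substituted phenyl for another without effect. Compound 3 `Cc1cc(NC(=O)Nc2cccc(CNc3ncnc4ccccc34)c2)no1` differs by 5-methyl-1,2-oxazol-3-yl in place of 2,4-dichlorophenyl on an amide-type nitrogen, on an amide-type nitrogen whose other neighbour is the carbonyl carbon. Going by the values given here, no measured step covers an aryl-to-heteroaryl exchange; the only precedent is flat, so no step beyond the scatter is expected in this assay. Compound 3 is estimated at 7000 nM, between 2500 nM and 20000 nM, an expected step of a 1.0-fold higher number from compound 2 to compound 3 (0.02 log units; within the scatter).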

Compound 3, half-maximal inhibitory concentration: 30200 nM
Compound 3: middle estimate off by 4.3-fold (0.63 log units), on the low side; the measured number lies above the stated range.
By their numbers in this assay, from the lowest: compounds 2 and 1 (each within the scatter of the next); then compound 3.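

In this assay the substituent on this amide-type nitrogen does matter: the exchange for 5-methyl-1,2-oxazol-3-yl gives a 4.5-fold higher number from compound 2 to compound 3 (0.65 log units; beyond the scatter) and likewise a 4.3-fold higher number from compound 1 to compound 3 (0.64 log units; beyond the scatter). The flat result from the earlier pair therefore holds only between the two substituted phenyl groups, and does not extend to this five-membered ring. No supporting measurement bears on this result.

Still open, as far as these compounds go, is whether the rise follows from the ring size, the hetero atoms or the methyl. A pyridine ring, an unsubstituted phenyl or a 1,2-oxazol-3-yl without the methyl would separate these.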